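Cytotoxicity notes: from compound 3 to compound 4

The source may hold more compounds than are shown below. What is called first, only, known or untested is meant among the compounds shown, and "the series" means these compounds.

Compound 3 `N#Cc1ccc(-c2nc(CO[C@@H]3COc4nc([N+](=O)[O-])cn4C3)cs2)cc1` stands at the assay limit in an ADME assay on Vero cells (Chlorocebus sabaeus) for cytotoxicity, with a stated time of 72 h; a lower number here means a stronger inhibitor, a higher number a weaker inhibitor: compound 3 gives > 128000 nM, which is a limit and not a number. Its neighbours show the same picture. Compound 1 `O=[N+]([O-])c1cn2c(n1)OC[C@@H](OCc1ccc(-c3ccc(OC(F)F)cc3)s1)C2` gives > 128000 nM, a limit. Compound 2 `O=[N+]([O-])c1cn2c(n1)OC[C@@H](OCc1csc(-c3ccc(C(F)(F)F)cc3)n1)C2` gives > 128000 nM, also a limit. Among the measured compounds shown here, the one measured step, a step that the two limits leave unreadable from compound 2 to compound 3, cannot be read because of the limit of > 128000 nM in this assay, at which 3 of the 3 values shown sit. Compound 4 `COc1ccc(-c2nc(CO[C@@H]3COc4nc([N+](=O)[O-])cn4C3)cs2)cc1F` differs from compound 3 by 3-fluoro-4-methoxyphenyl in place of 4-cyanophenyl on an aromatic carbon. For the measured compounds named here, no measured step gives a readable size for this change; every value shown sits at the limit, so no step beyond the scatter is expected in this assay. The expected step of a number no higher from compound 3 to compound 4 (the limit leaves the size open) is essentially nil. Compound 4 is therefore expected at 128000 nM, within 64000 nM to 300000 nM, most likely reported again only as a limit.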

Compound 4, half-maximal inhibitory concentration: > 128000 nM
Compound 4: no number, only a limit (the forecaster's own chance of this, stated with the estimate: 85%); the middle value lies on the limit itself.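

No step can be read from compound 3 to compound 4, because both values are limits and not numbers: the limit of > 128000 nM in this assay, at which 4 of the 4 values shown sit.

The compounds shown leave open what effect either aryl group has on cytotoxicity in this series.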